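The source may report more compounds than this note shows. Statements on the series, on what has been measured and on what is new or still open speak of the compounds shown alone.

Measured so far in an assay for positive allosteric modulation of metabotropic glutamate receptor 3 (Rattus norvegicus); on this read-out lower numbers stand for an effect already at smaller amounts and higher numbers for an effect only at larger amounts of compound:
- compound 1 `Cc1ncc(OCCCCOc2ccc(C(=O)CC(C)(C)C)c(O)c2C)cc1C(=O)O`: 79 nM
- compound 2 `Cc1c(OCCCCOc2cncc(C(=O)O)c2)ccc(C(=O)CC(C)(C)C)c1O`: 180 nM

Compound 2 stands at the higher of the two numbers recorded in this assay; its nearest neighbour is compound 1, and the step of a 2.3-fold higher number from compound 1 to compound 2 (0.36 log units; beyond the scatter) separates them. Within the data shown here, that step exchanges a methyl for hydrogen on an aromatic carbon and is the only measured step in the set.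

Compound 3 `Cc1c(OCCCCOc2ccc(Cl)c(C(=O)O)c2)ccc(C(=O)CC(C)(C)C)c1O` is still to be measured in this assay. Relative to compound 2 it carries 3-carboxy-4-chlorophenyl in place of 5-carboxypyridin-3-yl on an oxygen on a saturated carbon. Among the measured compounds shown here, no measured step covers an exchange of this kind: the one recorded step, methyl to hydrogen, concerns a different part of the aryl ether and says nothing about replacing the ring itself. The working expectation is therefore a step of a 1.2-fold lower number from compound 2 to compound 3 (0.08 log units; within the scatter) of no clear direction, with wide uncertainty. Compound 3 is estimated at 150 nM in this assay, in the range 50 nM to 450 nM.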

Compound 3, half-maximal effective concentration: 130 nM
Compound 3: middle estimate off by 1.2-fold (0.06 log units), on the high side; measured number inside the range.
By their numbers in this assay, from the lowest: compounds 1, 3 and 2 (each within the scatter of the next, the first and the last beyond it).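

In this assay, 3-carboxy-4-chlorophenyl is tolerated on an oxygen on a saturated carbon, which the earlier methyl-to-hydrogen step could not show: the ring exchange gives a 1.4-fold lower number from compound 2 to compound 3 (0.14 log units; within the scatter) and a 1.6-fold higher number from compound 1 to compound 3 (0.22 log units; within the scatter), both within the scatter. A ring nitrogen is therefore not required at this position for a value in this range, although the exchange removes that nitrogen and introduces chlorine together, so their separate contributions cannot be read. No supporting data bear on why the exchange is tolerated.

From the compounds shown here alone, all three compounds carry a carboxylic acid on this ring, so it remains open whether a tetrazole or a primary amide could take its place. Going by these compounds, it also remains open whether a ring with bromine or a methyl group in place of the chlorine would stay in the same range.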